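The compounds below may be only part of what the source reports. "The series", "measured", "known", "first", "only" and "open" are said of these compounds alone.

In a toxicity assay on HT-29 cells (Homo sapiens) for cytotoxicity (a lower number here means that less compound is tolerated, a higher number that more compound is tolerated), compound 1 `COCCn1nc(C(=O)N[C@H]2COc3ccccc3N(C)C2=S)nc1Cc1ccccc1` gives > 100000 nM, which is a limit of the assay and not a number. Compound 2 `CN1C(=S)[C@@H](NC(=O)c2nc(Cc3ccccc3)n(CCCCCC#N)n2)COc2ccccc21` gives > 100000 nM, which is also a limit. Within the data shown here, the one measured step, a step that the two limits leave unreadable from compound 1 to compound 2, therefore has no readable size, and the evidence amounts to the limit of > 100000 nM in this assay, at which 2 of the 2 values shown sit.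

Replacing one group on compound 2 gives compound 3 `CN1C(=S)[C@@H](NC(=O)c2nc(Cc3ccccc3)n(C3CCCC3)n2)COc2ccccc21`, with cyclopentyl in place of 5-cyanopentyl on an aromatic nitrogen. The measured step also changed the group on this nitrogen, so it is the one that bears on the new change. Because of the limit of > 100000 nM in this assay, at which 2 of the 2 values shown sit, no step beyond the scatter is expected in this assay, in either direction. The expected step is a number no higher from compound 2 to compound 3 (the limit leaves the size open). Compound 3 is estimated at 100000 nM, with an expected range from 50000 nM to 200000 nM, and it will most likely be reported only as a limit again.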

Compound 3, half-maximal cytotoxic concentration: > 100000 nM
Compound 3: only a limit was reported (the forecaster's own chance of this, stated with the estimate: 90%); the middle value sits exactly at the limit.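

Compound 2 and compound 3, like compound 1, sit at a limit of the assay and not at a number, so no step among them can be read: the limit of > 100000 nM in this assay, at which 3 of the 3 values shown sit.

As far as these compounds go, whether any group on this aromatic nitrogen would give a readable number in this assay stays open.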